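The source may report more compounds than this note shows. Statements on the series, on what has been measured and on what is new or still open speak of the compounds shown alone.

Compound 1 `O=C(/C=C/c1cccc(Cl)c1Cl)Nc1cc2c(Nc3ccc(F)c(Cl)c3)ncnc2cc1O[C@H]1CCOC1` was tested in a functional assay on HeLa cells (Homo sapiens) for cytotoxicity, read by MTT assay, with a stated time of 72 h; on this read-out lower numbers stand for stronger inhibition and higher numbers for weaker inhibition. In this assay compound 1 gives 30500 nM. Going by the values given here, this is the only number in the set, so compound 1 cannot be ranked against anything: compound 2 `COc1cc2ncnc(Nc3ccc(F)c(Cl)c3)c2cc1NC(=O)/C=C/c1ccc(C#N)cc1` was entered in this assay, but for compound 2 the entry reads "not determined" (no result reported), so no result was reported for it. Compound 3 `COc1ccc(/C=C/C(=O)Nc2cc3c(Nc4ccc(F)c(Cl)c4)ncnc3cc2O[C@H]2CCOC2)c(OC)c1OC` shares the core of compound 1 and differs from it at a single site, by 2,3,4-trimethoxyphenyl in place of 2,3-dichlorophenyl on a double-bonded chain carbon bound to a double-bonded chain carbon. Among the compounds with values here, no measured pair shows what such a swap does here, so the step in this assay from compound 1 to compound 3 cannot be read off any data; the expectation is a step within the usual scatter, in no fixed direction, a 1.1-fold lower number from compound 1 to compound 3 (0.04 log units; within the scatter). On that basis compound 3 is estimated at 28000 nM in this assay, with a range from 9000 nM to 90000 nM.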

Compound 3, half-maximal inhibitory concentration: 4830 nM
The estimate for compound 3 lay 5.8-fold (0.76 log units) above the measured number; the measured number lies below the stated range.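

In this assay, the group on this double-bonded chain carbon clearly matters: 2,3,4-trimethoxyphenyl in place of 2,3-dichlorophenyl gives a 6.3-fold lower number from compound 1 to compound 3 (0.80 log units; beyond the scatter), so with the shared core unchanged, this one site can move the number beyond the usual scatter. The entering group has more heavy atoms and carries hydrogen-bond acceptors where the leaving group has none, but a single pair cannot show which of these differences counts. No other measurement here helps to explain the shift.

From the compounds shown here alone, it remains open whether the lower number comes from adding the methoxy groups or from losing the chlorine atoms, and a plain phenyl ring at this site would help to separate the two. Going by these compounds, how a phenyl ring carrying an amine or a carboxylic acid would behave here also remains unknown.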